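A few compounds are considered here, and "the series" means these few. Any claim that something is new, unique, unknown or untested is made for them only; others in the source may bear on it.

Measured so far:

Compound 1 `Nc1c(C2=NCCN2)cnn1-c1cccc(Cl)c1`. In an ADME assay on Vero cells (Chlorocebus sabaeus) for cytotoxicity, read by CellTiter-Glo and ATP content, with a stated time of 72 h (a higher number here means that more compound is tolerated, a lower number that less compound is tolerated), compound 1 gives > 500000 nM, which is a limit of the assay rather than a number.
Compound 2 `Nc1c(C2=NCCN2)cnn1-c1ccc(Cl)cc1`. Compound 2 gives > 500000 nM, again a limit.
Compound 3 `Nc1c(C2=NCCN2)cnn1-c1ccc(Br)cc1`. Compound 3 gives > 500000 nM, also a limit.

Compound 1 and compound 2 have the same atoms joined differently; the difference between the two cores is not broken down here. From compound 2 to compound 3 the change is bromo in place of chloro on an aromatic carbon. The step it made is a step that the two limits leave unreadable from compound 2 to compound 3. Both values sit at the limit of > 500000 nM in this assay, at which 3 of the 3 values shown sit.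

Compound 4 `Nc1c(C2=NCCN2)cnn1-c1cccc(Br)c1` is not yet measured. It differs from compound 1 by bromo in place of chloro on an aromatic carbon. Among the measured compounds shown here, this is the same kind of change as the one from compound 2 to compound 3, but the place differs: there the bromo sits para to a large group, here meta to a large group. In this assay the step is expected to be a step that the limit leaves unreadable from compound 1 to compound 4. This expectation rests on compound 1 giving > 500000 nM, a limit. The expected reading for compound 4 is 700000 nM, with a likely range from 400000 nM to 2000000 nM.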

Compound 4, half-maximal cytotoxic concentration: 352000 nM
Compound 4: the middle estimate sits 2.0-fold (0.30 log units) above what was measured; measured number outside the range, below it.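

In this assay, bromo in place of chloro on an aromatic carbon gives an at least 1.4-fold lower number from compound 1 to compound 4 (0.15 log units; that floor lies within the scatter). This is only a floor and it lies within the usual scatter, so the step may be real or may be no more than scatter. The same change on the core of compound 2 cannot be read, because both compounds there sit at one limit, which leaves no second step to set beside the first and does not show whether the change carries from one core to the other: the limit of > 500000 nM in this assay, at which 3 of the 4 values shown sit.

The compounds shown leave open how an amine or a carboxylic acid in place of the chloro or bromo would read in this assay. They also leave open what a longer chain at that place would give.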